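The compounds below may be only part of what the source reports. "The series", "measured", "known", "first", "only" and "open" are said of these compounds alone.

Measured in an assay on U2OS cells for inhibition of secreted frizzled-related protein 1 (Homo sapiens), read by a luciferase reporter, with a stated time of 18 h; on this read-out lower numbers stand for an effect already at smaller amounts and higher numbers for an effect only at larger amounts of compound:
compound 1, `O=C(c1ccccn1)N1CCC(NS(=O)(=O)c2cc(S(=O)(=O)c3ccccc3)ccc2C(F)(F)F)CC1`: 230 nM
compound 2, `O=C(c1cccnc1)N1CCC(NS(=O)(=O)c2cc(S(=O)(=O)c3ccccc3)ccc2C(F)(F)F)CC1`: 120 nM
compound 3, `O=C(O)c1cccc(S(=O)(=O)N2CCC(NS(=O)(=O)c3cc(S(=O)(=O)c4ccccc4)ccc3C(F)(F)F)CC2)c1`: 190 nM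

Compound 1 stands highest of the three numbers, yet both separations stay within the scatter: a 1.2-fold lower number from compound 1 to compound 3 (0.08 log units; within the scatter) and a 1.9-fold lower number from compound 1 to compound 2 (0.28 log units; within the scatter). Compound 4, `O=C(CC1CCNCC1)N1CCC(NS(=O)(=O)c2cc(S(=O)(=O)c3ccccc3)ccc2C(F)(F)F)CC1`, is not yet measured. Its change from compound 1 is (piperidin-4-yl)methyl in place of pyridin-2-yl on a carbonyl carbon. The measured steps that bear on it are those altering the cap on the same amide-type nitrogen in a ring; besides the two above, a 1.6-fold higher number from compound 2 to compound 3 (0.20 log units; within the scatter) is also within the scatter, though none of them introduces a non-aromatic ring. The step is therefore expected to remain small, a 1.3-fold higher number from compound 1 to compound 4 (0.12 log units; within the scatter). Compound 4 is estimated at 300 nM, with a range from 100 nM to 900 nM.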

Compound 4, half-maximal effective concentration: 210 nM
Estimate against measurement, compound 4: 1.4-fold (0.15 log units) above, and the stated range covers the measured number.
By their numbers in this assay, from the lowest: compounds 2, 3, 4 and 1 (each within the scatter of the next).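

In this assay, the carbonyl carbon on the amide-type nitrogen in a ring now carries a non-aromatic ring, and (piperidin-4-yl)methyl in place of pyridin-2-yl stays within the scatter (a 1.1-fold lower number from compound 1 to compound 4 (0.04 log units; within the scatter)). The same holds for the steps from the pyridin-3-yl compound (a 1.8-fold higher number from compound 2 to compound 4 (0.24 log units; within the scatter)) and the (3-carboxyphenyl)sulfonyl compound (a 1.1-fold higher number from compound 3 to compound 4 (0.04 log units; within the scatter)), so among these compounds this position does not require an aromatic ring. No available evidence explains this result. Still open, from the compounds shown here alone, is whether an open-chain amine, a longer carbon chain or a carboxylic acid on this carbonyl carbon would also stay within the scatter.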